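Opening an amine on the side chain of a crowded aryl piperazine

The source may report more compounds than this note shows. Statements on the series, on what has been measured and on what is new or still open speak of the compounds shown alone.

Measured compounds:
Compound 1, `CCCCC(N)c1cc(C(F)(F)F)ccc1N1CCN(C(=O)CCc2ccc(Cl)cc2Cl)CC1`, gives 190 nM in an assay on HEK293 cells for displacement of a labelled ligand from Melanocortin receptor 4 (Homo sapiens); a lower number here means a stronger inhibitor, a higher number a weaker inhibitor.
Compound 2, `CCC(C)[C@H](NCC1CCCO1)c1cc(C(F)(F)F)ccc1N1CCN(C(=O)CCc2ccc(Cl)cc2Cl)CC1`, gives 780 nM in this assay.
Compound 3, `CCC(C)[C@H](NC(=O)OC)c1cc(C(F)(F)F)ccc1N1CCN(C(=O)CCc2ccc(Cl)cc2Cl)CC1`, gives 2400 nM in this assay.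

Compound 3 stands at the weak end of this small set: its number is the highest of the three, separated from compound 2 by a 3.1-fold higher number from compound 2 to compound 3 (0.49 log units; beyond the scatter) and from compound 1 by a 13-fold higher number from compound 1 to compound 3 (1.10 log units; beyond the scatter). The common thread is the nitrogen on the benzylic carbon: free in compound 1, carrying a tetrahydrofuranylmethyl in compound 2, and capped as a methyl carbamate in compound 3, each step moving the number upward.

Compound 4, `CC(C)C[C@H](NC(=O)CCN)c1cc(C(F)(F)F)ccc1N1CCN(C(=O)CCc2ccc(Cl)cc2Cl)CC1`, has not yet been measured. Its change from compound 3 is 1-(((2-aminoethyl)carbonyl)amino)-3-methylbutyl in place of 1-((methoxycarbonyl)amino)-2-methylbutyl on an aromatic carbon. The carbamate gives way to an amide whose chain ends in a primary amine, so a basic nitrogen returns, though at a distance from the benzylic carbon, and the branching of the alkyl chain shifts.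

Among the measured compounds shown here, the steps that bear on this are the capping steps a 3.1-fold higher number from compound 2 to compound 3 (0.49 log units; beyond the scatter) and a 13-fold higher number from compound 1 to compound 3 (1.10 log units; beyond the scatter). Restoring an amine is expected to pull the number back down, but only partly, since the new amine sits farther out and the amide remains. Compound 4 is therefore estimated at 1000 nM, between 300 nM and 3000 nM, a step of a 2.4-fold lower number from compound 3 to compound 4 (0.38 log units; beyond the scatter).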

Compound 4, inhibition constant: 25 nM
Compound 4: the middle estimate sits 40-fold (1.60 log units) above what was measured; the measured number lies below the stated range.
By their numbers in this assay, from the lowest: compound 4; then compound 1; then compound 2; then compound 3.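

In this assay, the 1-(((2-aminoethyl)carbonyl)amino)-3-methylbutyl group on this aromatic carbon gives the lowest number of the four compounds, and all three steps to it are beyond the scatter (a 96-fold lower number from compound 3 to compound 4 (1.98 log units; beyond the scatter); a 31-fold lower number from compound 2 to compound 4 (1.49 log units; beyond the scatter); a 7.6-fold lower number from compound 1 to compound 4 (0.88 log units; beyond the scatter)). Among the earlier compounds, the number rose whenever the side-chain nitrogen carried a substituent, but compound 4 goes against that pattern: this nitrogen is part of an amide whose chain ends in a primary amine, and its number still falls below that of compound 1, which has a free amine. So at this position a capped nitrogen is compatible with a low number, and no outside measurement is available to explain the size of this gain.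

The step from compound 3 to compound 4 replaces the carbamate with the aminoethyl amide and also changes the 2-methylbutyl skeleton to a 3-methylbutyl one, so these compounds cannot show how much of the gain belongs to each change. Going by these compounds, the role of the end amine also remains open, and it could be tested with the same amide ending in a hydroxyl group, a carboxylic acid or a longer chain carrying the amine.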